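Methyl-to-hydrogen step on an aromatic oxygen in the series

This account rests on a few compounds, and the source may have more. Where it says the series, first, only, none or still open, it means among the compounds named here.

Measured compounds:
Compound 1 `COc1cc(/C=C/C(=O)OCCCO[N+](=O)[O-])ccc1OCCCO[N+](=O)[O-]` gives in a functional assay on HOP-62 cells (Homo sapiens) for cytotoxicity, read by resazurin assay, with a stated time of 72 h (a lower number here means a stronger inhibitor, a higher number a weaker inhibitor), a value of > 50000 nM, which is a limit of the assay and not a number.
Compound 2 `O=C(/C=C/c1ccc(O)c(O)c1)OCc1c(-c2ccccc2)no[n+]1[O-]` gives 6120 nM in this assay.
Compound 3 `COc1cc(/C=C/C(=O)OCc2c(-c3ccccc3)no[n+]2[O-])ccc1O` gives 8660 nM in this assay.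

Compound 1 sits at the limit of > 50000 nM in this assay, at which 1 of the 3 values shown sits, so only a limit is known for it. Compounds 2 and 3 share a core that is not that of compound 1; the difference between the two cores is not broken down here. Within the core of compound 3, the change hydrogen in place of methyl on an oxygen on an aromatic ring gives a 1.4-fold lower number from compound 3 to compound 2 (0.15 log units; within the scatter).

Compound 4 `O=C(/C=C/c1ccc(OCCCO[N+](=O)[O-])c(O)c1)OCCCO[N+](=O)[O-]` is not yet measured in this assay. It differs from compound 1 by hydrogen in place of methyl on an oxygen on an aromatic ring, the same change at the same place as that made from compound 3 to compound 2. Among the compounds shown the change occurs twice, and its one measured instance lies within the scatter. The step is therefore expected to be small again, a step that the limit leaves unreadable from compound 1 to compound 4, resting on a 1.4-fold lower number from compound 3 to compound 2 (0.15 log units; within the scatter). Because compound 1 stands at the limit of > 50000 nM in this assay, at which 1 of the 3 values shown sits, compound 4 is expected to stay near that limit as well. Compound 4 is estimated at 60000 nM, with a range from 25000 nM to 200000 nM.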

Compound 4, half-maximal inhibitory concentration: 10000 nM
The estimate for compound 4 lay 6.0-fold (0.78 log units) above the measured number; measured number below the stated range.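

In this assay, the change from methoxy to hydroxy on the core of compound 1 gives an at least 5.0-fold lower number from compound 1 to compound 4 (0.69 log units; beyond the scatter) and so counts as a real step on this core. Its size does not carry over unchanged from one core to the other: the same change on two cores in this assay, a 1.4-fold lower number (0.15 log units; within the scatter) from compound 3 to compound 2 and an at least 5.0-fold lower number (0.69 log units; beyond the scatter) from compound 1 to compound 4, at least 3.5-fold (0.54 log units) apart, beyond the scatter of two such steps. This rests on only two instances and gives neither a cause for the gap nor an upper bound for the new step, and compound 1 has only a limit of the assay and not a number: the limit of > 50000 nM in this assay, at which 1 of the 4 values shown sits.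

Which of the differences between the two cores governs the size of the step remains open, as does the size of the step on any further core. Also open, from the compounds shown here alone, is whether a longer chain on the same oxygen, such as ethoxy, or an amine in place of the hydroxy would give a number nearer to that of compound 4 or to the limit of compound 1.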